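Ether-to-Thioether Swap and Fibroblast Cytotoxicity Limits

The source may hold more compounds than are shown below. What is called first, only, known or untested is meant among the compounds shown, and "the series" means these compounds.

Measured compounds:
Compound 1 `CCC(CC)Oc1ccc(CN[C@H]2CC(C(=O)O)=C[C@@H](OC(CC)CC)[C@@H]2NC(C)=O)cc1`: in an ADME assay on cells (Fibroblast, Gallus gallus) for cytotoxicity, read by CCK-8 assay, with a stated time of 48 h (on this read-out lower numbers stand for higher toxicity in this test and higher numbers for lower toxicity in this test), compound 1 gives > 200000 nM, which is a limit of the assay and not a number.
Compound 2 `CCC(CC)Oc1cccc(CN[C@H]2CC(C(=O)O)=C[C@@H](OC(CC)CC)[C@@H]2NC(C)=O)c1`: in this assay compound 2 gives > 200000 nM, again a limit of the assay.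
Compound 3 `CCC(CC)O[C@@H]1C=C(C(=O)O)C[C@H](NCc2ccc(SC(C)CC)cc2)[C@H]1NC(C)=O`: in this assay compound 3 gives > 200000 nM, also a limit of the assay.

Compound 1 and compound 2 share the same atoms joined differently; the difference between the two cores is not broken down here. Compound 3 arises from compound 1 by (sec-butyl)sulfanyl in place of (pentan-3-yl)oxy on an aromatic carbon. The step in this assay is a step that the two limits leave unreadable from compound 1 to compound 3, and it stays unreadable due to the limit of > 200000 nM in this assay, at which 3 of the 3 values shown sit.

Compound 4 `CCC(CC)O[C@@H]1C=C(C(=O)O)C[C@H](NCc2cccc(SC(C)CC)c2)[C@H]1NC(C)=O` has not yet been measured. It arises from compound 2 by (sec-butyl)sulfanyl in place of (pentan-3-yl)oxy on an aromatic carbon. Within the data shown here, this is the same kind of change as the one from compound 1 to compound 3, but not the same: in compound 3 the entering group sits para to a large group, whereas in compound 4 it sits meta to a large group.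

Among the measured compounds shown here, since every value so far rests on the limit (the limit of > 200000 nM in this assay, at which 3 of the 3 values shown sit), the expected step from compound 2 to compound 4 is estimated as a step that the limit leaves unreadable from compound 2 to compound 4, resting on compound 2 at > 200000 nM and compound 3 at > 200000 nM. Compound 4 is therefore expected to give about 250000 nM in this assay, with the range estimated from 120000 nM to 600000 nM, most likely reported again only as a limit.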

Compound 4, half-maximal cytotoxic concentration: > 200000 nM
Compound 4 was reported as a limit (the forecaster's own chance of this, stated with the estimate: 85%); the middle value is on the limit's open side.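

In this assay compound 4 gives > 200000 nM, which is a limit of the assay and not a number. Compound 2 and compound 4 therefore yield no readable step for the exchange of (pentan-3-yl)oxy for (sec-butyl)sulfanyl: the limit of > 200000 nM in this assay, at which 4 of the 4 values shown sit. The compounds shown leave open at what concentration any of the four would harm these cells, and whether this exchange alters that concentration.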